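Cyclic peptide series: quaternary side chain in place of amine

The source may hold more compounds than are shown below. What is called first, only, known or untested is meant among the compounds shown, and "the series" means these compounds.

Compound 2 `CC(C)C[C@@H]1NC(=O)[C@H](CCCNC(=N)N)NC(=O)[C@H](CCCN)NC(=O)[C@H](CC(=O)O)NC(=O)[C@H](CCCCN)NC(=O)CCNC1=O` in an assay on COS-7 cells for inhibition of disintegrin and metalloproteinase domain-containing protein 8 (Homo sapiens), read by ELISA, with a stated time of 6 h (a higher number here means a weaker inhibitor, a lower number a stronger inhibitor), gives > 5000 nM, which is a limit of the assay rather than a number. Compound 1 `CC(C)C[C@@H]1NC(=O)[C@H](CCCNC(=N)N)NC(=O)[C@H](CCN)NC(=O)[C@H](CC(=O)O)NC(=O)[C@H](CCCCN)NC(=O)CCNC1=O` in this assay gives > 5000 nM, likewise a limit. The step that the two limits leave unreadable from compound 1 to compound 2 is thus unreadable, and the limit of > 5000 nM in this assay, at which 2 of the 2 values shown sit, is all that the measured pair shows. Compound 3 `CC(C)C[C@@H]1NC(=O)[C@H](CCCNC(=N)N)NC(=O)[C@H](CCCC[N+](C)(C)C)NC(=O)[C@H](CC(=O)O)NC(=O)[C@H](CCCCN)NC(=O)CCNC1=O` carries a group of 5 heavy atoms (4 carbon, 1 nitrogen; no ring) in place of one nitrogen atom, on a saturated chain carbon, three bonds along the chain from a saturated ring carbon. Going by the values given here, no measured step bears on this change, so the step that the limit leaves unreadable from compound 2 to compound 3 is expected, with a limit again the most likely outcome. Compound 3 is estimated at 8000 nM, within 2500 nM to 40000 nM.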

Compound 3, half-maximal inhibitory concentration: > 10000 nM
Compound 3: only a limit was reported; the forecaster's own chance of this, stated with the estimate: 85%; middle value at least 1.2-fold (0.09 log units) from the limit.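

In this assay compound 3 gives > 10000 nM, a limit, and its steps from compound 1 and compound 2 cannot be read. From the compounds shown here alone, whether any of these side chains gives a measurable half-maximal inhibitory concentration remains open.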